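This account rests on a few compounds, and the source may have more. Where it says the series, first, only, none or still open, it means among the compounds named here.

Of the compounds shown here, two have been measured. Compound 1, with the structure `CN(C)CCCCCSC1=Nc2ccccc2C(CC(=O)NCc2ccccc2)N1c1ccc(-c2ccc(F)cc2)cc1`, gives 4180 nM in an assay on cells for inhibition of Voltage-dependent T-type calcium channel subunit alpha-1H (Homo sapiens), read by patch clamp; a lower number here means a stronger inhibitor, a higher number a weaker inhibitor. Compound 2, with the structure `O=C(CC1c2ccccc2N=C(SCCCCCN2CCCC2)N1c1ccc(-c2ccc(F)cc2)cc1)NCc1ccc(F)cc1`, gives 4880 nM in this assay. Compound 2 thus stands at the higher of the two numbers, but its nearest neighbour is compound 1, and the gap between the two values lies within the usual scatter of repeated measurements, so the two values show no order. Compounds 1 and 2 differ in more than one place, so no single step can be read between them.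

Compound 3, with the structure `O=C(CC1c2ccccc2N=C(SCCCCCN2CCCC2)N1c1ccc(-c2ccc(F)cc2)cc1)NCc1ccccc1`, has not yet been measured. It differs from compound 2 in one place: hydrogen in place of fluoro on an aromatic carbon. With no measured step of this kind in hand, no change beyond the scatter is expected in this assay, in either direction, for the step from compound 2 to compound 3. Compound 3 is therefore estimated to give 4500 nM in this assay, between 2000 nM and 10000 nM, the step of a 1.1-fold lower number from compound 2 to compound 3 (0.04 log units; within the scatter) being expected to fall within the scatter.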

Compound 3, half-maximal inhibitory concentration: 260 nM
The estimate for compound 3 lay 17-fold (1.24 log units) above the measured number; the whole stated range lies above it.
By their numbers in this assay, from the lowest: compound 3; then compounds 1 and 2 (each within the scatter of the next).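

In this assay, replacing the 4-fluorobenzyl group with benzyl gives a large change in the direction of stronger inhibition (a 19-fold lower number from compound 2 to compound 3 (1.27 log units; beyond the scatter)), so a single fluoro on this aromatic carbon, para to a large group, separates compound 2 from the far stronger compound 3. The other end of the molecule matters as well: with benzyl held constant, pyrrolidin-1-yl in place of dimethylamino also gives a large change (a 16-fold lower number from compound 1 to compound 3 (1.21 log units; beyond the scatter)), which the near-equal values of compounds 1 and 2 could not reveal, and among these three compounds only compound 3 carries both benzyl and pyrrolidin-1-yl. Nothing available explains why either change has so large an effect.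

The compounds shown leave open whether the fluoro costs as much when dimethylamino stands at the chain end, and so whether the two changes act independently or depend on each other. They also leave open how chloro or methoxy would fare at the aromatic carbon, and how piperidin-1-yl or morpholin-4-yl would compare with pyrrolidin-1-yl at the end of the chain.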